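Removing the amide nitrogen: an ester in place of a carbamate

The source may report more compounds than this note shows. Statements on the series, on what has been measured and on what is new or still open speak of the compounds shown alone.

Three compounds have been measured in a functional assay on SK-LU-1 cells (Homo sapiens) for antiproliferative activity, read by sulforhodamine B assay, with a stated time of 48 h, tested at 50 uM; a lower number here means less inhibition, a higher number more inhibition at the concentration tested (going by the name of the read-out):
Compound 1 `COc1cccc(C(=O)Oc2cc3c(cc2C)[C@@H](C(C)C)CC=C3C)c1` gives 24.2%.
Compound 2 `CC1=CC[C@H](C(C)C)c2cc(C)c(OC(=O)Nc3ccccc3)cc21` gives 100%.
Compound 3 `COc1cccc(C(=O)Oc2cc3c(C)ccc(C(C)C)c3cc2C)c1` gives 30.6%.

Compound 2 stands highest of the three, beyond the scatter from both others. Compound 4 `CC1=CC[C@H](C(C)C)c2cc(C)c(OC(=O)c3ccccc3)cc21` differs from it by phenyl in place of anilino on a carbonyl carbon. Going by the values given here, one measured step bears on this: a number 75.8 percentage points higher from compound 1 to compound 2 (beyond the scatter), where anilino took the place of 3-methoxyphenyl on the same carbonyl carbon. Compound 4 undoes that exchange, though with a plain phenyl rather than 3-methoxyphenyl, so a large drop in this assay is expected, in the order of a number 65 percentage points lower from compound 2 to compound 4 (beyond the scatter). Compound 4 is therefore estimated at 35%, likely between 15% and 65%.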

Compound 4, a percentage reported as inhibition, at one concentration (the size of the read-out at that concentration, not a potency): 37%
The estimate for compound 4 lay 2 percentage points below the measured number, within the range that was stated.
By their numbers in this assay, from the lowest: compounds 1, 3 and 4 (each within the scatter of the next, the first and the last beyond it); then compound 2.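

In this assay phenyl in place of anilino on the carbonyl carbon brings a number 63 percentage points lower from compound 2 to compound 4 (beyond the scatter) and so shows that the large loss does not depend on a methoxy group on the ring. Hydrogen in place of methoxy on the aromatic carbon gives a number 12.8 percentage points higher from compound 1 to compound 4 (beyond the scatter) as a modest step, so at this position the change from anilino to an aromatic ring counts for far more than the methoxy group does. Nothing available explains the drop.

Still open, as far as these compounds go, is whether the nitrogen needs its aromatic ring at all. A methylamino or benzylamino group on the same carbonyl carbon would test that.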